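Swapping an amide for a urea on a shared core

A few compounds are considered here, and "the series" means these few. Any claim that something is new, unique, unknown or untested is made for them only; others in the source may bear on it.

Measured so far:
compound 1 `O=C(Nc1cccc(-n2cc(-c3ccncc3)c(-c3ccc(Cl)c(O)c3)n2)c1)Nc1ccc(Cl)c(Cl)c1` — > 32500 nM
compound 2 `COc1cc(-c2nn(-c3cccc(NC(=O)c4ccc(Cl)c(C(F)(F)F)c4)c3)cc2-c2ccncc2)ccc1Cl` — > 32500 nM
compound 3 `O=C(Nc1cccc(-n2cc(-c3ccncc3)c(-c3ccc(Cl)c(O)c3)n2)c1)Nc1cc(C(F)(F)F)cc(C(F)(F)F)c1` — 23400 nM

In a functional assay on SW-620 cells (Homo sapiens) for inhibition, read by sulforhodamine B assay, with a stated time of 48 h (on this read-out higher numbers stand for lower toxicity in this test and lower numbers for higher toxicity in this test), compound 1 gives only a limit of the assay, > 32500 nM. Compound 2 likewise reaches only a limit, > 32500 nM. Among the measured compounds shown here, compound 3 is the one compound with a number, giving 23400 nM. Compound 2 therefore stands at the top of what this assay can report, sharing that place with compound 1 (the limit of > 32500 nM in this assay, at which 2 of the 3 values shown sit). Compound 4 `COc1cc(-c2nn(-c3cccc(NC(=O)Nc4cccc(C(F)(F)F)c4)c3)cc2-c2ccncc2)ccc1Cl` is not yet measured. Compared with compound 2 it carries (3-(trifluoromethyl)phenyl)amino in place of 4-chloro-3-(trifluoromethyl)phenyl on a carbonyl carbon. For the measured compounds named here, no measured pair differs in just one place, so no step of known size guides this change. Since compound 1 and compound 3, both ureas, also sit at or near the limit, compound 4 is expected to stay in the same region. The expected step from compound 2 to compound 4 is an at least 1.0-fold lower number from compound 2 to compound 4 (0.03 log units; that floor lies within the scatter), none beyond the scatter. Compound 4 is estimated at 30000 nM, with a range from 15000 nM to 60000 nM.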

Compound 4, concentration lethal to 50% of the cells: 50000 nM
Compound 4: middle estimate off by 1.7-fold (0.22 log units), on the low side; the range from low to high includes it.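

Among the compounds shown here, no step from compound 2 to compound 4 can be read, because compound 2 gives only a limit: the limit of > 32500 nM in this assay, at which 2 of the 4 values shown sit. The compounds shown leave open whether (3-(trifluoromethyl)phenyl)amino in place of 4-chloro-3-(trifluoromethyl)phenyl on a carbonyl carbon changes this read-out at all, and by how much.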